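The compounds below may be only part of what the source reports. "The series", "measured", "known", "first", "only" and "open" are said of these compounds alone.

For the measured compounds named here, compound 2 `O=C1NC(=O)/C(=C/c2ccc(OCCSc3nnc(-c4ccc(Br)cc4)[nH]3)cc2)S1` gives 39.5% in a functional assay on the whole organism (strain Wistar) with Rattus norvegicus as the target, with a stated time of 15 days, at a dose of 30 mg/kg by the oral route (a higher number here means a stronger effect of the compound at the dose given, a lower number a weaker effect), the higher of the two numbers so far; compound 1 `O=C1NC(=O)/C(=C/c2ccc(OCCSc3nnc(-c4ccccc4)[nH]3)cc2)S1` gives 26.4% in this assay, and the single measured step, a number 13.1 percentage points higher from compound 1 to compound 2 (beyond the scatter), is the only comparison in hand. Compound 3 `COc1ccc(-c2nnc(SCCOc3ccc(/C=C4\SC(=O)NC4=O)cc3)[nH]2)cc1` differs from compound 2 by methoxy in place of bromo on an aromatic carbon. Going by the values given here, no measured step exchanges bromo for methoxy, so the one step bears only loosely, and an estimated step of a number 6.5 percentage points lower from compound 2 to compound 3 (within the scatter) is not expected to exceed the scatter with any confidence. Compound 3 is therefore estimated at 33%, in a range from 18% to 48%.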

Compound 3, a percentage reported as activity, at one dose (the size of the read-out at that dose, not a potency): 59.5%
Beside the measured number, compound 3's estimate is 26.5 percentage points below it, outside the stated range (above it).
By their numbers in this assay, from the lowest: compound 1; then compound 2; then compound 3.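

At this place, para to a large group, the identity of the group matters and not only the replacement of hydrogen: going from 4-bromophenyl to 4-methoxyphenyl gives a number 20 percentage points higher from compound 2 to compound 3 (beyond the scatter) in this assay. Methoxy in place of hydrogen gives a number 33.1 percentage points higher from compound 1 to compound 3 (beyond the scatter), the largest step among the three compounds. No measurement bears on why methoxy exceeds bromo. Going by these compounds, whether a longer chain such as ethoxy extends the methoxy step remains open. So does the standing of an amine or a carboxylic acid at this place.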